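Chloro to nitro exchange on two related cores

This account rests on a few compounds, and the source may have more. Where it says the series, first, only, none or still open, it means among the compounds named here.

Compound 1 `CC(C)=CCC1Cc2c(OCCCOc3ccc(Cl)cc3)cc(=O)n(CCCO)c2CC1(C)C` gives 0% in a functional assay on PANC-1 cells (Homo sapiens) for inhibition, read by MTT assay, with a stated time of 24 h, tested at 10 uM; a higher number here means more inhibition at the concentration tested (going by the name of the read-out), a lower number less inhibition. Compound 2 `CC(C)=CCC1Cc2c(OCCCOc3ccc([N+](=O)[O-])cc3)cc(=O)n(CCCO)c2CC1(C)C` differs from compound 1 by nitro in place of chloro on an aromatic carbon, and in this assay compound 2 gives 0%; the step reads no change at the digits printed from compound 1 to compound 2 (within the scatter). Compound 3 `CC(C)=CCC/C(C)=C/CC1Cc2c(OCCCOc3ccc(Cl)cc3)cc(=O)n(CCCO)c2CC1(C)C` carries a second core, which differs from the core of compound 1 by 3-methylbut-2-en-1-yl in place of hydrogen on a saturated chain carbon bound to a double-bonded chain carbon; in this assay compound 3 gives 0%, and the step reads no change at the digits printed from compound 1 to compound 3 (within the scatter). Compound 4 `CC(C)=CCC/C(C)=C/CC1Cc2c(OCCCOc3ccc([N+](=O)[O-])cc3)cc(=O)n(CCCO)c2CC1(C)C` is not yet measured. It differs from compound 3 by nitro in place of chloro on an aromatic carbon, the same change made once before from compound 1 to compound 2, at a place described in identical words, so it counts as the same change. That earlier exchange stayed within the scatter, and all three measured compounds sit at one level. The expected step is no change at the digits printed from compound 3 to compound 4 (within the scatter), resting on the earlier step of no change at the digits printed from compound 1 to compound 2 (within the scatter) and on the level of compound 3 at 0%. Compound 4 is accordingly estimated at 0%, with a range from 0% to 10%.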

Compound 4, a percentage reported as inhibition, at one concentration (the size of the read-out at that concentration, not a potency): 9.8%
The estimate for compound 4 lay 9.8 percentage points below the measured number; the measured number falls inside the stated range.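

Nitro in place of chloro gives a number 9.8 percentage points higher from compound 3 to compound 4 (within the scatter) in this assay, and set beside the earlier exchange, it carries across the two cores without a gap beyond the scatter: the same change on two cores in this assay, no change at the digits printed (within the scatter) from compound 1 to compound 2 and a number 9.8 percentage points higher (within the scatter) from compound 3 to compound 4, 9.8 percentage points apart, within the scatter of two such steps

The addition of 3-methylbut-2-en-1-yl gives a number 9.8 percentage points higher from compound 2 to compound 4 (within the scatter), and it likewise carries across the chloro and nitro compounds: the same change on two cores in this assay, no change at the digits printed (within the scatter) from compound 1 to compound 3 and a number 9.8 percentage points higher (within the scatter) from compound 2 to compound 4, 9.8 percentage points apart, within the scatter of two such steps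

Among the compounds shown here, with every step inside the scatter, this shows only that neither change moves the read-out beyond the scatter at the single concentration tested; it does not show that either change raises inhibition, and it gives no potency, nor does it test whether a step of real size would transfer between cores.

The compounds shown leave open whether an amine or a carboxylic acid in place of chloro on the aromatic ring would move the read-out beyond the scatter. Also open, as far as these compounds go, is whether a longer chain between the phenoxy group and the shared core would do so.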